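Pyrrolidinyl for cyclopentylamino on the shared purine-nucleoside scaffold

The compounds below may be only part of what the source reports. "The series", "measured", "known", "first", "only" and "open" are said of these compounds alone.

Measured compounds:
compound 1 `CCNc1nc2c(SCc3ccccc3)ncnc2n1C1O[C@H](CO)[C@@H](O)[C@H]1O` — 9.5 nM
compound 2 `OC[C@H]1OC(n2c(NC3CCCC3)nc3c(SCc4ccccc4)ncnc32)[C@H](O)[C@@H]1O` — 0.64 nM

Both compounds were characterised in an assay on cell membranes for binding affinity to Equilibrative nucleoside transporter 1 (Homo sapiens); on this read-out higher numbers stand for weaker inhibition and lower numbers for stronger inhibition. Within the data shown here, compound 2 stands lowest of the two numbers; its nearest neighbour is compound 1, and the step of a 15-fold lower number from compound 1 to compound 2 (1.17 log units; beyond the scatter) is the only measured change in the set, consisting of cyclopentyl in place of ethyl on a nitrogen on an aromatic ring.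

Compound 3 `OC[C@H]1OC(n2c(N3CCCC3)nc3c(SCc4ccccc4)ncnc32)[C@H](O)[C@@H]1O` has not yet been measured. It differs from compound 2 by pyrrolidin-1-yl in place of cyclopentylamino on an aromatic carbon. Among the measured compounds shown here, the one measured step concerns the size of the carbon group on that nitrogen, not the removal of the hydrogen-bond donor that this change brings, so no measured step bears directly on the change from compound 2 to compound 3. Given that the group that enters is the cyclopentylamino of compound 2 closed into a ring without its donor, a weaker number is expected for compound 3, but with wide uncertainty. The expected step is a 9.4-fold higher number from compound 2 to compound 3 (0.97 log units; beyond the scatter) for compound 3. Compound 3 is therefore estimated at 6 nM, within a range from 0.8 nM to 50 nM.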

Compound 3, inhibition constant: 410 nM
Beside the measured number, compound 3's estimate is 68-fold (1.83 log units) below it; measured number above the stated range.
By their numbers in this assay, from the lowest: compound 2; then compound 1; then compound 3.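

In this assay, the position between two ring nitrogen atoms proves far less tolerant than the earlier pair suggested: pyrrolidin-1-yl in place of cyclopentylamino gives a 640-fold higher number from compound 2 to compound 3 (2.81 log units; beyond the scatter), and pyrrolidin-1-yl in place of ethylamino gives a 43-fold higher number from compound 1 to compound 3 (1.64 log units; beyond the scatter). The earlier step, a 15-fold lower number from compound 1 to compound 2 (1.17 log units; beyond the scatter), changed only the carbon group on a nitrogen that kept its hydrogen, whereas here the entering group counts 0 hydrogen-bond donors and its ring contains the nitrogen, and compound 3 has the highest number of the three, whichever of the other two it is set against. The compounds shown offer no measured explanation for this large rise in the number.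

The change from compound 2 to compound 3 removes the nitrogen's hydrogen and joins the nitrogen into the ring in a single step, so the compounds shown cannot tell the two apart. A cyclopentyl(methyl)amino group, which has no hydrogen on that nitrogen but keeps the carbon ring outside it, would separate them, while piperidin-1-yl would show whether the larger ring follows compound 3.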